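A few compounds are considered here, and "the series" means these few. Any claim that something is new, unique, unknown or untested is made for them only; others in the source may bear on it.

Measured so far in this series: compound 1 `COc1ccc(C(CCCCCN2CCc3cc(OC)c(OC)cc3C2)Sc2ccc(C)cc2)cc1OC` at 330 nM; compound 2 `COc1ccc2c(c1)CCN(CCCCCC(Sc1ccc(C)cc1)c1ccc(OC)c(OC)c1)C2` at 3090 nM.

In a functional assay on S1B1-20 cells (Homo sapiens) (a lower number here means a stronger inhibitor, a higher number a weaker inhibitor), compound 1 stands at the lower of the two numbers. Compound 2 sits well above it. Within the data shown here, the only measured step, a 9.4-fold higher number from compound 1 to compound 2 (0.97 log units; beyond the scatter), lies beyond the scatter. Compound 3 `COc1cc2c(cc1OC)CN(CCCCCC(Sc1ccc(C)cc1)c1ccc(OC(F)(F)F)cc1)CC2` differs from compound 1 by 4-(trifluoromethoxy)phenyl in place of 3,4-dimethoxyphenyl on a saturated chain carbon bound to a saturated chain carbon and a sulfur. Among the measured compounds shown here, no measured step touches that position, so the step from compound 1 to compound 2 is only an indirect guide; a modest rise in the number is expected, a 3.0-fold higher number from compound 1 to compound 3 (0.48 log units; beyond the scatter). Compound 3 is estimated at 1000 nM, with a range from 300 nM to 4000 nM.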

Compound 3, half-maximal inhibitory concentration: 2070 nM
Compound 3: the middle estimate sits 2.1-fold (0.32 log units) below what was measured; low and high end bracket the measured number.
By their numbers in this assay, from the lowest: compound 1; then compounds 3 and 2 (each within the scatter of the next).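

In this assay, among these compounds, the aryl group on a saturated chain carbon bound to a saturated chain carbon and a sulfur clearly matters: 4-(trifluoromethoxy)phenyl in place of 3,4-dimethoxyphenyl gives a 6.3-fold higher number from compound 1 to compound 3 (0.80 log units; beyond the scatter), the first reading at this position. Neither replacement nor 3,4-dimethoxyphenyl can yet be tied to any cause, as no supporting data bear on this step.

As far as these compounds go, it remains open whether the step follows the loss of the two methoxy groups or the entry of trifluoromethoxy. A plain phenyl or a 4-methoxyphenyl group at this position would separate the two.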